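Furan-3-yl on the core of compound 3

The source may hold more compounds than are shown below. What is called first, only, known or untested is meant among the compounds shown, and "the series" means these compounds.

In a functional assay on CUTLL1 cells (Homo sapiens) for inhibition, read by resazurin assay, with a stated time of 48 h, in the presence of a further agent that is not named here (a higher number here means that more compound is needed for the effect, a lower number that less compound is needed), compound 1 (`COc1ccc(-c2cnc(N)nc2C2CC2)cc1`) gives > 100000 nM as a limit, not a number. Among the compounds with values here, compound 2 (`C=Cc1cnccc1-c1cnc(N)nc1C1CC1`) gives 29000 nM as the one measured number so far. Compound 3 (`Nc1ncc(-c2ccncc2)cn1`) gives > 100000 nM as a limit too, so it stands at the limit of > 100000 nM in this assay, at which 2 of the 3 values shown sit, and offers no number to start a step from.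

The change furan-3-yl in place of hydrogen on an aromatic carbon puts furan-3-yl in place of hydrogen on an aromatic carbon, next to the ring nitrogen and ortho to a pyridin-4-yl group, and gives compound 4 (`Nc1ncc(-c2ccncc2)c(-c2ccoc2)n1`) .

Within the data shown here, no measured pair shows a change of this kind, so the expectation rests on the values alone. Among the measured compounds shown here, the direction expected is toward less compound needed, with compound 2 at 29000 nM as the only guide to where a measurable value lies. Another limit reading remains quite possible. From the compounds shown here alone, the expected step of an at least 3.3-fold lower number from compound 3 to compound 4 (0.52 log units; beyond the scatter) is a modest one, and its true size stays open while the starting point is a limit. In this assay the estimated value for compound 4 is 30000 nM with 8000 nM to 100000 nM as the expected range.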

Compound 4, half-maximal effective concentration: > 100000 nM
Compound 4: no number, only a limit; the forecaster's own chance of this, stated with the estimate: 40%; middle value at least 3.3-fold (0.52 log units) from the limit.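

Compound 3 and compound 4 each give a limit and not a number, so no step can be read between them: the limit of > 100000 nM in this assay, at which 3 of the 4 values shown sit.

The compounds shown leave open whether furan-3-yl in place of hydrogen on an aromatic carbon changes the response at all, and which change on the core of compound 3 would give a measurable number.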